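Series notes: isoxazolyl for phenyl on the fused core

A few compounds are considered here, and "the series" means these few. Any claim that something is new, unique, unknown or untested is made for them only; others in the source may bear on it.

Measured compounds: compound 1 `O=C1Nc2ccc(N3CCOC3=O)cc2C(CNC(=O)c2ccc(F)cc2)(C(F)(F)F)O1`, compound 2 `CCC1(COC(=O)Nc2ccc(F)cc2)OC(=O)Nc2ccc(Cl)cc21`, compound 3 `O=C1Nc2ccc(-c3ccccc3)cc2C(CNC(=O)c2ccc(F)cc2)(C(F)(F)F)O1`. In an assay for inhibition of very long chain fatty acid elongase 6 (Homo sapiens) (a higher number here means a weaker inhibitor, a lower number a stronger inhibitor), compound 1 gives 67 nM, compound 2 gives 2260 nM and compound 3 gives 1480 nM. Among the compounds with values here, compound 3 and compound 2 fall within the scatter of each other; compound 3 sits far from compound 1, the step of a 22-fold higher number from compound 1 to compound 3 (1.34 log units; beyond the scatter) being the only one-place change in this assay.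

Compound 4 `O=C1Nc2ccc(-c3ccon3)cc2C(CNC(=O)c2ccc(F)cc2)(C(F)(F)F)O1` differs from compound 3 by 1,2-oxazol-3-yl in place of phenyl on an aromatic carbon. Within the data shown here, the single step bearing on this position, a 22-fold higher number from compound 1 to compound 3 (1.34 log units; beyond the scatter), shows that replacing a five-membered ring with two hetero atoms at this carbon by phenyl raises the number strongly. Going back to a small ring carrying hetero atoms is therefore expected to lower the number in this assay, though the ring is not the one in compound 1, so a partial return is estimated: a 3.7-fold lower number from compound 3 to compound 4 (0.57 log units; beyond the scatter). Compound 4 is expected to give 400 nM, within 100 nM to 1500 nM.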

Compound 4, half-maximal inhibitory concentration: 121 nM
For compound 4 the middle estimate is 3.3-fold (0.52 log units) above the measured one; the range from low to high includes it.
By their numbers in this assay, from the lowest: compounds 1 and 4 (each within the scatter of the next); then compounds 3 and 2 (each within the scatter of the next).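

In this assay, a 12-fold lower number from compound 3 to compound 4 (1.09 log units; beyond the scatter) shows that the high number on phenyl is not specific to the comparison with 2-oxo-1,3-oxazolidin-3-yl: 1,2-oxazol-3-yl at this aromatic carbon also gives a much lower number than phenyl. With a 1.8-fold higher number from compound 1 to compound 4 (0.26 log units; within the scatter), these two five-membered rings cannot be told apart in this assay. No available evidence explains why phenyl differs from both.

Still open, from the compounds shown here alone, is whether ring size or the hetero atoms govern this position. A pyridin-2-yl ring or a simple amine at this carbon could help separate the two.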